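Fluoro for methyl on the sulfur-linked phenyl ring

This account rests on a few compounds, and the source may have more. Where it says the series, first, only, none or still open, it means among the compounds named here.

Compound 1 `Cc1ccc(SCc2ccc(C(=O)Nc3ccccc3N)cc2)cc1` is the reference of this set. In a functional assay on HeLa cells (Homo sapiens) for inhibition, read by CCK-8 assay, with a stated time of 72 h, tested at 8 uM (a lower number here means less inhibition of growth, a higher number more inhibition of growth at the concentration tested), compound 1 gives 79.2%, the highest of the three numbers measured. Compound 2 `Nc1ccccc1NC(=O)/C=C/c1ccc(CSc2cccc(F)c2)cc1` sits far lower, giving 18.6% in this assay, and compound 3 `Nc1ccccc1NC(=O)/C=C/c1ccc(CSc2ccc(C(F)(F)F)cn2)cc1` is lowest, giving 6.82%. Both of these carry a different linker from compound 1, so their gap to compound 1 is not attributable to any single change. Among the compounds with values here, the one measured step, a number 11.8 percentage points lower from compound 2 to compound 3 (beyond the scatter), swaps the aryl group on the sulfur and is modest in size.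

Compound 4 `Nc1ccccc1NC(=O)c1ccc(CSc2ccc(F)cc2)cc1` keeps the linker and core of compound 1 and differs only in fluoro in place of methyl on an aromatic carbon. Within the data shown here, the change sits on the same sulfur-linked ring that was altered from compound 2 to compound 3, but there is no measured step of the same kind. A step within or just beyond the scatter is therefore expected in this assay, with no strong basis for either direction. Compound 4 is estimated at 70%, range 50% to 88%, which corresponds to an expected a number 9.2 percentage points lower from compound 1 to compound 4 (within the scatter).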

Compound 4, percent growth inhibition at one concentration: 79.3%
The estimate for compound 4 lay 9.3 percentage points below the measured number; the range from low to high includes it.
By their numbers in this assay, from the lowest: compound 3; then compound 2; then compounds 1 and 4 (each within the scatter of the next).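

In this assay, fluoro in place of methyl on an aromatic carbon, para to a large group, gives a number 0.1 percentage points higher from compound 1 to compound 4 (within the scatter), so with the linker and core of compound 1 this position takes either group without a step beyond the scatter. The earlier step, a number 11.8 percentage points lower from compound 2 to compound 3 (beyond the scatter), exchanged the whole aryl group on the sulfur under a different linker, so it gave no reading of a single-atom change at this position. Nothing available here explains why the two groups give matching numbers.

The compounds shown leave open whether an amine, a carboxylic acid or a methoxy group at this position would also keep the number in this range. Both numbers also come from a single concentration, so any difference in potency between compound 1 and compound 4 remains unresolved.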